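Acylated threonine octyl and tetradecyl amides: cytotoxicity notes

This account rests on a few compounds, and the source may have more. Where it says the series, first, only, none or still open, it means among the compounds named here.

Measured so far in a functional assay on HepG2 cells (Homo sapiens) for cytotoxicity, read by MTT assay, with a stated time of 48 h; on this read-out higher numbers stand for weaker inhibition and lower numbers for stronger inhibition:
- compound 1 `CCCCCCCCNC(=O)[C@@H](NC(=O)/C=C/c1ccccc1)[C@@H](C)O` gives 55600 nM
- compound 2 `C/C=C/C=C/C(=O)N[C@H](C(=O)NCCCCCCCC)[C@@H](C)O` gives 102000 nM
- compound 3 `CCCCCCCCCCCCCCNC(=O)[C@@H](NC(=O)/C=C/c1ccccc1)[C@@H](C)O` gives 150000 nM

Compound 2 differs from compound 1 by prop-1-en-1-yl in place of phenyl on a double-bonded chain carbon bound to a double-bonded chain carbon; in this assay this change made a step of a 1.8-fold higher number from compound 1 to compound 2 (0.26 log units; within the scatter). Compound 3 differs from compound 1 by hexyl in place of hydrogen on a saturated chain carbon, eight bonds along the chain from an amide-type nitrogen, and here the step was a 2.7-fold higher number from compound 1 to compound 3 (0.43 log units; beyond the scatter). The values of compound 2 and compound 3 lie within the scatter of each other, so nothing is said about their order.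

Compound 4 `C/C=C/C=C/C(=O)N[C@H](C(=O)NCCCCCCCCCCCCCC)[C@@H](C)O` has not yet been measured. It differs from compound 3 by prop-1-en-1-yl in place of phenyl on a double-bonded chain carbon bound to a double-bonded chain carbon, which is the same change as that from compound 1 to compound 2, at the same place on the chain; the two cores differ as described under (hexyl in place of hydrogen on a saturated chain carbon, eight bonds along the chain from an amide-type nitrogen). For the measured compounds named here, only one earlier instance of this change is known, so the expectation rests on a single step.

Because a 1.8-fold higher number from compound 1 to compound 2 (0.26 log units; within the scatter) stayed within the scatter, the step from compound 3 to compound 4 in this assay is expected to be a 1.7-fold higher number from compound 3 to compound 4 (0.24 log units; within the scatter). Compound 4 is accordingly expected near 260000 nM. The lower end expected for compound 4 is estimated at 120000 nM. The upper end expected for compound 4 is estimated at 550000 nM. At this level the assay may report only a limit rather than a number.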

Compound 4, half-maximal inhibitory concentration: > 400000 nM
Compound 4 was reported as a limit (the forecaster's own chance of this, stated with the estimate: 30%); at least 1.5-fold (0.18 log units) between middle value and limit.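

In this assay compound 4 is reported only as a limit, > 400000 nM. Prop-1-en-1-yl in place of phenyl gives an at least 2.6-fold higher number from compound 3 to compound 4 (0.42 log units; beyond the scatter), and whether this change keeps its size when carried from the core of compound 1 to the core of compound 3 cannot be read: the same change on two cores in this assay, a 1.8-fold higher number (0.26 log units; within the scatter) from compound 1 to compound 2 and an at least 2.6-fold higher number (0.42 log units; beyond the scatter) from compound 3 to compound 4; the limit leaves it open whether they differ. Hexyl in place of hydrogen gives an at least 3.9-fold higher number from compound 2 to compound 4 (0.59 log units; beyond the scatter), so this change raises the number on both cores, but again no difference in size can be read: the same change on two cores in this assay, a 2.7-fold higher number (0.43 log units; beyond the scatter) from compound 1 to compound 3 and an at least 3.9-fold higher number (0.59 log units; beyond the scatter) from compound 2 to compound 4; the limit leaves it open whether they differ.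

The compounds shown leave open whether these two changes would behave alike with an amine or a carboxylic acid in place of phenyl, and whether a longer chain than hexyl in place of that hydrogen would raise the number further. On these data alone, the series also rests on two cores and a single pair for each change, so how far either change carries to other cores remains open.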